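Removal of one bromo from the sulfonamide aryl of compound 2

A few compounds are considered here, and "the series" means these few. Any claim that something is new, unique, unknown or untested is made for them only; others in the source may bear on it.

The series is a set of aminochlorophenyl ketones carrying a piperidine linked to an arylsulfonyl group and is followed in an assay on brain for displacement of a labelled ligand from 5-hydroxytryptamine receptor 4 (Cavia porcellus), with a stated time of 30 min, in the presence of a further agent that is not named here; a higher number here means a weaker inhibitor, a lower number a stronger inhibitor. Compound 1 `COc1ccc(S(=O)(=O)N2CCC(CCC(=O)c3cc(Cl)c(N)cc3OC)CC2)cc1` is recorded in this assay as "not determined" (no result reported). Compound 2 `COc1cc(N)c(Cl)cc1C(=O)CCC1CCN(CCNS(=O)(=O)c2cc(Br)c(N)c(Br)c2)CC1` gives 8.7 nM in this assay, and compound 3 `COc1ccc(S(=O)(=O)CCCN2CCC(CCC(=O)c3cc(Cl)c(N)cc3OC)CC2)cc1` gives 12.2 nM; these two numbers lie within the scatter of each other, so neither can be set apart from the other. For the measured compounds named here, compound 2 thus sits among the measured numbers with no repeated-measurement distance to its only numbered neighbour.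

Compound 4 `COc1cc(N)c(Cl)cc1C(=O)CCC1CCN(CCNS(=O)(=O)c2ccc(N)c(Br)c2)CC1` differs from compound 2 as follows: hydrogen in place of bromo on an aromatic carbon. Going by the values given here, no measured pair in the set carries this kind of change, so the step has no direct precedent here. Because compound 2 gives 8.7 nM, compound 4 is expected to remain in the same region, with a step of a 1.8-fold higher number from compound 2 to compound 4 (0.26 log units; within the scatter) that is estimated to be small and, if anything, toward a weaker inhibitor. For compound 4 the estimated value is 16 nM, with a range from 5 nM to 50 nM.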

Compound 4, inhibition constant: 5.3 nM
Beside the measured number, compound 4's estimate is 3.0-fold (0.48 log units) above it, and the stated range covers the measured number.
By their numbers in this assay, from the lowest: compounds 4, 2 and 3 (each within the scatter of the next, the first and the last beyond it).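

In this assay the exchange of 4-amino-3,5-dibromophenyl for 4-amino-3-bromophenyl gives a 1.6-fold lower number from compound 2 to compound 4 (0.22 log units; within the scatter) and so leaves compound 2 and compound 4 indistinguishable. For the compounds shown here, this is the first pair that differs in one place, and it shows that, on this ring, hydrogen is accepted in place of bromo at a position ortho to the amino group, with the other bromo kept. Going by these compounds alone, the single bromo of compound 4 is therefore enough for a number in the same range as that of compound 2. No measurement offered here bears on why the two compounds read alike.

From the compounds shown here alone, whether the remaining bromo can also give way to hydrogen stays open, as does the reading with chloro or methyl at either position. Also open, going by these compounds, is how a longer chain between the piperidine and the sulfonamide would read on the 4-amino-3-bromophenyl group.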